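Opening the piperidine amide of compound 1

The compounds below may be only part of what the source reports. "The series", "measured", "known", "first", "only" and "open" are said of these compounds alone.

Compound 1, with the structure `O=C(c1cccc(Nc2ncc(F)c(Nc3ccc(F)cc3)n2)c1)N1CCCCC1`, was tested in a functional assay on A549 cells (Homo sapiens) for antiproliferative activity, read by sulforhodamine B assay, with a stated time of 3 days (on this read-out lower numbers stand for stronger inhibition of growth and higher numbers for weaker inhibition of growth), and gives 13200 nM, which is the higher of the two numbers measured here, so it is the weaker inhibitor of growth. Compound 2, with the structure `CN(C)CC(=O)Nc1cccc(Nc2ncc(F)c(Nc3ccc(F)cc3)n2)c1`, gives 1180 nM in the same assay. Among the compounds with values here, the one measured step, an 11-fold lower number from compound 1 to compound 2 (1.05 log units; beyond the scatter), came with (((dimethylamino)methyl)carbonyl)amino in place of (piperidin-1-yl)carbonyl on an aromatic carbon.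

Compound 3, with the structure `O=C(NCCO)c1cccc(Nc2ncc(F)c(Nc3ccc(F)cc3)n2)c1`, differs from compound 1 by (2-hydroxyethyl)amino in place of piperidin-1-yl on a carbonyl carbon. This also removes the piperidin-1-yl ring from the amide, as in the step to compound 2, but the change sits on the carbonyl carbon and the entering group is (2-hydroxyethyl)amino rather than a new amide. Within the data shown here, because the only comparable step, an 11-fold lower number from compound 1 to compound 2 (1.05 log units; beyond the scatter), was large, a lower number is expected for compound 3 as well, though a smaller step. The expected step for compound 3 is estimated as a 3.3-fold lower number from compound 1 to compound 3 (0.52 log units; beyond the scatter). Compound 3 is therefore estimated at 4000 nM, with a range from 1500 nM to 12000 nM.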

Compound 3, concentration for 50% growth inhibition: 11900 nM
The estimate for compound 3 lay 3.0-fold (0.47 log units) below the measured number; the measured number falls inside the stated range.
By their numbers in this assay, from the lowest: compound 2; then compounds 3 and 1 (each within the scatter of the next).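

In this assay, putting (2-hydroxyethyl)amino in place of piperidin-1-yl on the carbonyl carbon gives a 1.1-fold lower number from compound 1 to compound 3 (0.05 log units; within the scatter), so removing the ring and adding this open chain leaves the number unchanged within the scatter. Losing the piperidine ring is therefore not enough to produce the drop seen with compound 2, and the comparison between the two replacement groups shows a 10-fold higher number from compound 2 to compound 3 (1.00 log units; beyond the scatter), which leaves compound 2 with the lowest number of the three. Nothing measured here explains this difference between the two groups.

From the compounds shown here alone, it remains open whether the lower number of compound 2 follows from its dimethylamino group or from the way its amide is attached to the aromatic carbon. A (2-(dimethylamino)ethyl)carbamoyl group, which places the same amine on the carbonyl carbon, would separate these two features.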